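Hydroxyalkyl side-chain variation on a shared core

The source may hold more compounds than are shown below. What is called first, only, known or untested is meant among the compounds shown, and "the series" means these compounds.

The series varies a hydroxyalkyl chain on a shared core. Compound 1 `C[C@H](O)CCn1nc2c(Br)c(Br)c(Br)c(Br)c2n1` and compound 2 `CC(O)CCn1nc2c(Br)c(Br)c(Br)c(Br)c2n1` have been run in a functional assay on CCRF-CEM cells (Homo sapiens) for antiproliferative activity, read by MTT assay, with a stated time of 24 h, tested at 12.5 uM; a higher number here means a weaker effect of the compound at the concentration tested, a lower number a stronger effect. Compound 1 gives 126% in this assay, and compound 2 gives 106%; neither compound shows an effect beyond the scatter at this concentration. Among the measured compounds shown here, the single measured comparison is a number 20 percentage points lower from compound 1 to compound 2 (beyond the scatter), and the only structural difference behind it is the fact that one of compounds 1 and 2 is drawn with a defined configuration and the other without, at the place where they differ. Compound 2 therefore stands as the lower of the two numbers, its nearest neighbour being compound 1.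

Compound 3 `OCC(O)Cn1nc2c(Br)c(Br)c(Br)c(Br)c2n1` is not yet measured. Relative to compound 2 it carries 1,2-dihydroxyethyl in place of 2-hydroxypropyl on a saturated chain carbon bound to an aromatic nitrogen. For the measured compounds named here, no measured step concerns a change of this kind: the step in hand turns on the drawing of a stereocentre, not on the exchange of one hydroxyalkyl chain for another. The expected step is a number 2 percentage points higher from compound 2 to compound 3 (within the scatter), that is nothing beyond the scatter. For compound 3 the estimated value in this assay is 108%, with a range from 88% to 128%.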

Compound 3, a percentage reported as activity, at one concentration (the size of the read-out at that concentration, not a potency): 78%
Estimate against measurement, compound 3: 30 percentage points above, outside the stated range (below it).
By their numbers in this assay, from the lowest: compound 3; then compound 2; then compound 1.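

The exchange of 2-hydroxypropyl for 1,2-dihydroxyethyl on a saturated chain carbon bound to an aromatic nitrogen moves the read-out in this assay in a way the drawing of a stereocentre could not address: a number 28 percentage points lower from compound 2 to compound 3 (beyond the scatter), and against the compound with the defined configuration, a number 48 percentage points lower from compound 1 to compound 3 (beyond the scatter). Compound 3, at 78%, is thus the lowest of the three, and the identity of the hydroxyalkyl chain itself now has a measured bearing on the result. Nothing in hand explains this step.

The change swaps a carbon for an oxygen in one move, so the second hydroxyl and the chain make-up cannot be separated here. As far as these compounds go, whether the trend continues with a longer chain carrying two hydroxyl groups, or with an amine or a carboxylic acid on the chain, stays open.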